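Propyl to tert-butyl on a ring nitrogen

A few compounds are considered here, and "the series" means these few. Any claim that something is new, unique, unknown or untested is made for them only; others in the source may bear on it.

Measured so far:
Compound 1 `COc1ccc(Nc2cc(-c3ccncc3)ncn2)cc1`: > 10000 nM in an ADME assay on BaF3 cells (Mus musculus) for cytotoxicity (a lower number here means that less compound is needed, a higher number that more compound is needed for the effect), a limit of the assay rather than a number.
Compound 2 `CCCn1ncc2c(Nc3ccc(OC(F)(F)F)cc3)ncnc21`: 6600 nM in this assay.

For the measured compounds named here, compound 2 holds the only measured number here. Compound 1 accounts for (the limit of > 10000 nM in this assay, at which 1 of the 2 values shown sits).

Compound 3 `CC(C)(C)n1ncc2c(Nc3ccc(OC(F)(F)F)cc3)ncnc21` awaits measurement. It differs from compound 2 by tert-butyl in place of propyl on an aromatic nitrogen. Going by the values given here, no measured pair shows such a change, so in this assay only a small step is expected, in no set direction and not beyond the usual scatter. Compound 3 is therefore expected near 7000 nM, between 2500 nM and 20000 nM. This corresponds to an expected step of a 1.1-fold higher number from compound 2 to compound 3 (0.03 log units; within the scatter).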

Compound 3, half-maximal effective concentration: 7300 nM
Compound 3: middle estimate off by 1.0-fold (0.02 log units), on the low side; low and high end bracket the measured number.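

Swapping propyl for tert-butyl gives a 1.1-fold higher number from compound 2 to compound 3 (0.04 log units; within the scatter) in this assay and so offers the first comparison between compounds that differ in one place. On this aromatic nitrogen, the two groups cannot be told apart in this assay by their numbers, so this position tolerates either of them with no change beyond the usual scatter. Going by these compounds, whether a much smaller group such as methyl, or a chain carrying an amine, would shift the number on this nitrogen remains open. Nothing measured here explains why the two groups read alike.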